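Removing a Para Methyl From a Benzylsulfanyl Aryl Sulfonamide

The source may hold more compounds than are shown below. What is called first, only, known or untested is meant among the compounds shown, and "the series" means these compounds.

Measured compounds:
Compound 1, `Cc1ccc(CSc2cc(Cl)c(C)cc2S(=O)(=O)/N=C(\N)n2nc(C)cc2-c2ccccc2)cc1`: 62000 nM
Compound 2, `Cc1cc(S(=O)(=O)/N=C(\N)n2nccc2-c2ccccc2)c(SCc2ccc(C(F)(F)F)cc2)cc1Cl`: 17000 nM

In a functional assay on HeLa cells (Homo sapiens) for cytotoxicity, read by MTT assay, with a stated time of 72 h (on this read-out higher numbers stand for weaker inhibition and lower numbers for stronger inhibition), compound 1 gives 62000 nM, the highest of the two numbers. Compound 2 gives 17000 nM, a lower number lying beyond the scatter. Compound 3, `Cc1cc(-c2ccccc2)n(/C(N)=N/S(=O)(=O)c2cc(C)c(Cl)cc2SCc2ccccc2)n1`, has not been measured; it differs from compound 1 by one change: hydrogen in place of methyl on an aromatic carbon. Among the compounds with values here, no measured pair shows this change on its own, so its size is unknown; the expectation for a 1.1-fold lower number from compound 1 to compound 3 (0.05 log units; within the scatter) is a small step, most likely not beyond the scatter, in either direction. Compound 3 is therefore estimated at 55000 nM, within 20000 nM to 150000 nM.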

Compound 3, half-maximal inhibitory concentration: 5000 nM
Estimate against measurement, compound 3: 11-fold (1.04 log units) above; the measured number lies below the stated range.
By their numbers in this assay, from the lowest: compound 3; then compound 2; then compound 1.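

In this assay the change from 4-methylbenzyl to benzyl alone gives a 12-fold lower number from compound 1 to compound 3 (1.09 log units; beyond the scatter) and so shows that this position, para to a large group, is not indifferent to a single methyl. Compound 2 could not show this, as it differs from compound 1 in more than one place. No available evidence says why the number falls. As far as these compounds go, whether an amine or a carboxylic acid at this position would give a lower or a higher number remains open.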